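A Nitro Group Tested on Two Related Cores

This account rests on a few compounds, and the source may have more. Where it says the series, first, only, none or still open, it means among the compounds named here.

Compound 1 `CCN1C(=O)N(CC)C2C1NC(=S)N2/N=C/C=C/c1ccccc1` and compound 3 `CCN1C(=O)N(CC)C2C1NC(=O)N2/N=C/C=C/c1ccccc1` are close relatives, but the difference between their two cores is not broken down here. In a functional assay on RD cells (Homo sapiens) for inhibition, read by MTT assay, with a stated time of 72 h (on this read-out higher numbers stand for weaker inhibition and lower numbers for stronger inhibition), compound 1 gives 2250 nM, and in the same test compound 3 gives 2020 nM; these two numbers lie within the usual scatter of each other, so nothing separates them. Compound 2 `CCN1C(=O)N(CC)C2C1NC(=S)N2/N=C/C=C/c1ccccc1[N+](=O)[O-]` arises from compound 1 through a single change, (nitro in place of hydrogen on an aromatic carbon), and in this assay compound 2 gives 15300 nM, which means a 6.8-fold higher number from compound 1 to compound 2 (0.83 log units; beyond the scatter). Compound 4 `CCN1C(=O)N(CC)C2C1NC(=O)N2/N=C/C=C/c1ccccc1[N+](=O)[O-]`, still unmeasured, arises from compound 3 through the same change at the same place, (nitro in place of hydrogen on an aromatic carbon). For the measured compounds named here, the expectation for compound 4 rests on the one measured example of this change, because a 6.8-fold higher number from compound 1 to compound 2 (0.83 log units; beyond the scatter), and on the starting point, because compound 3 gives 2020 nM. Going by the values given here, with only one example to lean on, the step from compound 3 to compound 4 is expected to be a 5.9-fold higher number from compound 3 to compound 4 (0.77 log units; beyond the scatter). Compound 4 is therefore estimated at 12000 nM, with a likely range from 5000 nM to 30000 nM.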

Compound 4, half-maximal inhibitory concentration: 1930 nM
Beside the measured number, compound 4's estimate is 6.2-fold (0.79 log units) above it; the measured number lies below the stated range.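

In this assay, putting nitro in place of hydrogen on the core of compound 3 gives a 1.0-fold lower number from compound 3 to compound 4 (0.02 log units; within the scatter), so on this core the change leaves the number effectively where it was. The same change has therefore not carried over from one core to the other, and the gap between the two steps is real rather than noise: the same change on two cores in this assay, a 6.8-fold higher number (0.83 log units; beyond the scatter) from compound 1 to compound 2 and a 1.0-fold lower number (0.02 log units; within the scatter) from compound 3 to compound 4, 7.1-fold (0.85 log units) apart, beyond the scatter of two such steps. For the compounds shown here, this shows that a step measured on one core cannot simply be added to a compound on the other core, but with only one pair on each core it does not show what in the cores produces the gap, or how the change would behave on any further core.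

The compounds shown carry only hydrogen or nitro on this ring, and the nitro sits only ortho to a large group. From the compounds shown here alone, it remains open whether an amine or a carboxylic acid at that place, or a nitro elsewhere on the ring, would also give different steps on the two cores.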